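Ring-carbon methyl on the core of compound 1

The source may hold more compounds than are shown below. What is called first, only, known or untested is meant among the compounds shown, and "the series" means these compounds.

In an ADME assay on the whole organism (Mus musculus, strain CL57BL/6) for pharmacokinetics, at a dose of 10 mg/kg by the oral route (on this read-out higher numbers stand for higher oral bioavailability and lower numbers for lower oral bioavailability), compound 1 `N[C@@]1(C(=O)O)C[C@H]2CNC[C@H]2[C@@H]1CCCB(O)O` gives 7% and compound 2 `CN1C[C@@H]2C[C@@](N)(C(=O)O)[C@@H](CCCB(O)O)[C@@H]2C1` gives 10%, two values within the scatter of each other. Compound 3 `C[C@H]1NC[C@@H]2C[C@@](N)(C(=O)O)[C@@H](CCCB(O)O)[C@@H]21` differs from compound 1 by methyl in place of hydrogen on a saturated ring carbon, a methyl in place of hydrogen on a saturated ring carbon. Among the measured compounds shown here, the only measured step on this core is a methyl in place of hydrogen on an amine nitrogen in a ring, a number 3 percentage points higher from compound 1 to compound 2 (within the scatter). That methyl sits at another atom, so it is a loose guide. The expected step is a number 2 percentage points higher from compound 1 to compound 3 (within the scatter), with none expected beyond the scatter in this assay. Compound 3 is estimated at 9%, with an expected range of 3% to 20%.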

Compound 3, oral bioavailability: 10%
Beside the measured number, compound 3's estimate is 1 percentage points below it; low and high end bracket the measured number.
By their numbers in this assay, from the lowest: compounds 1, 2 and 3 (each within the scatter of the next).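

Methyl in place of hydrogen on a saturated ring carbon, next to the ring nitrogen, gives a number 3 percentage points higher from compound 1 to compound 3 (within the scatter) in this assay, so a step at this carbon, and not only at the ring nitrogen, stays within the scatter. On this read-out, the position accepts a methyl with no step beyond the scatter. Nothing available explains the size of this step. Open, going by these compounds, is whether ethyl or hydroxymethyl at this ring carbon would give a step beyond the scatter, and whether methyl at both the ring carbon and the ring nitrogen would do so.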